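The source may report more compounds than this note shows. Statements on the series, on what has been measured and on what is new or still open speak of the compounds shown alone.

Going by the values given here, compound 1, with the structure `COc1ccccc1-c1c(C)nn(-c2nc(-c3ccc(Cl)c(Cl)c3)c(SC(C)C)s2)c1C(=O)O`, is one of two compounds measured so far in a functional assay on BJAB cells (Homo sapiens) for antiproliferative activity, with a stated time of 4 days (a higher number here means that more compound is needed for the effect, a lower number that less compound is needed), where compound 1 gives 14700 nM. Among the compounds with values here, the other measured compound, compound 2, with the structure `COC(=O)c1c(Cc2ccccc2[N+](=O)[O-])c(C)nn1-c1nc(-c2ccc(Cl)c(Cl)c2)cs1`, differs from compound 1 in several places at once, so no single step connects them; in this assay compound 2 gives 377000 nM, and the gap between the two numbers lies beyond the scatter, with compound 1 standing at the lower of the two.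

Compound 3, with the structure `Cc1nn(-c2nc(-c3ccc(Cl)c(Cl)c3)c(SC(C)C)s2)c(C(=O)O)c1-c1cc(C#N)cc(C(F)(F)F)c1`, has not yet been measured in this assay. It differs from compound 1 in one place: 3-cyano-5-(trifluoromethyl)phenyl in place of 2-methoxyphenyl on an aromatic carbon. Within the data shown here, no step between measured compounds bears on this change, so no measured guide to its size exists. The account therefore rests on the position of compound 1 alone. The step from compound 1 to compound 3 is expected to be small, on either side of the scatter and most likely towards a lower number, as a 1.6-fold lower number from compound 1 to compound 3 (0.21 log units; within the scatter). In this assay compound 3 is expected to give about 9000 nM, within a range from 1500 nM to 50000 nM.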

Compound 3, half-maximal effective concentration: 3600 nM
Estimate against measurement, compound 3: 2.5-fold (0.40 log units) above, within the range that was stated.
By their numbers in this assay, from the lowest: compound 3; then compound 1; then compound 2.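

Going by these compounds alone, this is the first change in the study that can be read at a single place, the aromatic carbon next to the ring atom that bears a carboxy group and next to the ring atom that bears a methyl group. In this assay, 3-cyano-5-(trifluoromethyl)phenyl in place of 2-methoxyphenyl gives a 4.1-fold lower number from compound 1 to compound 3 (0.61 log units; beyond the scatter), so this place accepts a six-membered aromatic ring with more heavy atoms and a triple bond, and the number moves down rather than up. No measurement shown here accounts for the size or direction of this step.

Because the two rings differ in all their substituents at once, the compounds shown do not separate the loss of the methoxy group from the gain of the nitrile or of the trifluoromethyl group, and they leave open what an unsubstituted phenyl, a phenyl carrying only one of these groups, or a pyridine ring would give. They also leave open whether the step would hold with a methyl ester in place of the carboxy group, or with a longer chain in place of the isopropyl group on sulfur.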